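From dimethylamino to methoxymethoxy on a shared core

The source may hold more compounds than are shown below. What is called first, only, known or untested is meant among the compounds shown, and "the series" means these compounds.

In a functional assay on MCF7 cells (Homo sapiens) for antiproliferative activity, read by MTT assay, with a stated time of 48 h (on this read-out higher numbers stand for weaker inhibition and lower numbers for stronger inhibition), compound 1 (`CO[C@]1(C)/C=C/C(=O)/C(CO)=C\C[C@](C)(CCC=C(C)C)/C=C/[C@H]1OC(=O)C=C(C)C`) gives 14300 nM as its reading, while compound 2 (`CC(C)=CCC[C@]1(C)/C=C/[C@@H](OC(=O)C=C(C)C)[C@](C)(O)/C=C/C(=O)/C(CN(C)C)=C\C1`) gives 690 nM as the lower of the two numbers. That puts compound 2 ahead of compound 1 by a gap beyond the usual scatter, but these two compounds differ in more than one place. Compound 3 (`COCOC/C1=C/C[C@](C)(CCC=C(C)C)/C=C/[C@@H](OC(=O)C=C(C)C)[C@](C)(O)/C=C/C1=O`) has not yet been measured and differs from compound 2 in one place: methoxymethoxy stands in place of dimethylamino on a saturated chain carbon bound to a double-bonded ring carbon (methoxymethoxy in place of dimethylamino on a saturated chain carbon bound to a double-bonded ring carbon). Going by the values given here, no measured pair isolates a single change, so any expectation is indirect. It leans on compound 1, which has no dimethylamino group and reads 14300 nM as the weaker of the two. Some loss of inhibition is therefore expected, and the estimated change is a 5.8-fold higher number from compound 2 to compound 3 (0.76 log units; beyond the scatter) in this assay as a step beyond the scatter toward a higher number. Expected for compound 3 is 4000 nM as the middle value, with 1200 nM to 14000 nM as the likely span.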

Compound 3, half-maximal inhibitory concentration: 3120 nM
The estimate for compound 3 lay 1.3-fold (0.11 log units) above the measured number, within the range that was stated.
By their numbers in this assay, from the lowest: compound 2; then compound 3; then compound 1.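

In this assay, going by these compounds alone, the exchange gives the first reading of a single change on the shared core: a 4.5-fold higher number from compound 2 to compound 3 (0.66 log units; beyond the scatter). The group on a saturated chain carbon bound to a double-bonded ring carbon therefore bears on the reading, and dimethylamino and methoxymethoxy are not interchangeable there, although the step is modest and compound 3, which has no nitrogen in this group, still gives 3120 nM. No measurement at hand accounts for the size or direction of this step.

With only one exchange at this position, the compounds shown cannot tell whether the step follows from losing the nitrogen or from the replacement group as a whole. A morpholine, a pyrrolidine, or a plain methoxy on a saturated chain carbon bound to a double-bonded ring carbon would help to separate these readings, and a carboxylic acid there would show whether the position accepts a much different kind of group on this core.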